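A few compounds are considered here, and "the series" means these few. Any claim that something is new, unique, unknown or untested is made for them only; others in the source may bear on it.

Measured so far:
compound 1, `CCCCCOC(=O)C(O)Cn1cnc2c(N)ncnc21`, in a functional assay on HeLa cells (Homo sapiens) for cytotoxicity (a higher number here means that more compound is tolerated, a lower number that less compound is tolerated), compound 1 gives > 400 ug/mL
compound 2, `CCC(C)OC(=O)C(O)Cn1cnc2c(N)ncnc21`, in this assay compound 2 gives > 400 ug/mL

Compound 2 stands at a limit of the assay, not at a number, in this assay. Compound 1 likewise sits at a limit in this assay. Both readings fall on (the limit of > 400 ug/mL in this assay, at which 2 of the 2 values shown sit). For the measured compounds named here, the only measured step, a step that the two limits leave unreadable from compound 1 to compound 2, therefore cannot be read in size, and it shows only that the change on the oxygen next to a carbonyl group did not bring either compound inside the measurable range.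

Compound 3, `CCOC(=O)C(O)Cn1cnc2c(N)ncnc21`, is not yet measured. It differs from compound 2 by hydrogen in place of ethyl on a saturated chain carbon bound to an oxygen next to a carbonyl group and a saturated chain carbon. Going by the values given here, the one measured step that bears on this change, a step that the two limits leave unreadable from compound 1 to compound 2, gives no readable size. The estimated step, a step that the limit leaves unreadable from compound 2 to compound 3, is expected to be nothing beyond the scatter, with compound 3 most probably again reported only as a limit. Compound 3 is estimated at 500 ug/mL, with a range from 200 ug/mL to 1200 ug/mL.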

Compound 3, minimum cytotoxic concentration: > 400 ug/mL
Compound 3 ended at the assay's limit (the forecaster's own chance of this, stated with the estimate: 85%); the middle value does not contradict the limit.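

For the compounds shown here, compound 1, compound 2 and compound 3 all stand at a limit in this assay, so no step among them can be read in size: the limit of > 400 ug/mL in this assay, at which 3 of the 3 values shown sit. The compounds shown leave open how much of each compound is actually tolerated, and whether their differing chains change that at all.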